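The source may report more compounds than this note shows. Statements on the series, on what has been measured and on what is new or still open speak of the compounds shown alone.

Of the compounds shown here, three of one family have been tested in a functional assay on COLO 205 cells (Homo sapiens) for inhibition, read by sulforhodamine B assay, with a stated time of 48 h, tested at 50 uM; a lower number here means less inhibition of growth, a higher number more inhibition of growth at the concentration tested. Compound 2 `COc1cc(/C=C/C(=O)/C=C/c2cc(OC)c(OC)c(OC)c2)ccc1OCc1cn(CCCCOc2cc(=O)oc3ccccc23)nn1` gives 60%. Compound 1 `COc1cc(/C=C/C(=O)/C=C/c2ccco2)ccc1OCc1cn(CCCCOc2cc(=O)oc3ccccc23)nn1` gives 43%. Compound 3 `COc1cc(/C=C/C(=O)/C=C/c2cc(OC)c(OC)c(OC)c2)ccc1OCc1cn(CCCCCOc2cc(=O)oc3ccccc23)nn1` gives 51%; its number and that of compound 1 lie within the scatter of each other, and so do its number and that of compound 2.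

Within the data shown here, the one change that can be counted is the one between compound 2 and compound 1: furan-2-yl in place of 3,4,5-trimethoxyphenyl on a double-bonded chain carbon bound to a double-bonded chain carbon With it, this assay moves a number 17 percentage points lower from compound 2 to compound 1 (beyond the scatter). How the core of compound 3 differs from the core of compound 2 is not broken down here.

Compound 4 `COc1cc(/C=C/C(=O)/C=C/c2ccco2)ccc1OCc1cn(CCCCCOc2cc(=O)oc3ccccc23)nn1` has not yet been measured. It differs from compound 3 by the same change: furan-2-yl in place of 3,4,5-trimethoxyphenyl on a double-bonded chain carbon bound to a double-bonded chain carbon Because this change gave a number 17 percentage points lower from compound 2 to compound 1 (beyond the scatter), a step of similar size is expected from compound 3 to compound 4, namely a number 17 percentage points lower from compound 3 to compound 4 (beyond the scatter). On that basis compound 4 is estimated to give 34% in this assay, with a likely range from 22% to 46%. This rests on a single earlier step, so the expectation is tentative.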

Compound 4, percent growth inhibition at one concentration: 33%
The estimate for compound 4 lay 1 percentage points above the measured number, and the stated range covers the measured number.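

In this assay, furan-2-yl in place of 3,4,5-trimethoxyphenyl gives a number 18 percentage points lower from compound 3 to compound 4 (beyond the scatter) and so repeats the earlier step on a second core. The two steps match in size, which means that in this series the change carried over from the core of compound 2 to the core of compound 3 without a detectable loss or gain: the same change on two cores in this assay, a number 17 percentage points lower (beyond the scatter) from compound 2 to compound 1 and a number 18 percentage points lower (beyond the scatter) from compound 3 to compound 4, 1 percentage points apart, within the scatter of two such steps. This does not show that the change would behave the same way on any other core, and two steps at a single concentration in one cell line give only its size, not the reason for it.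

The compounds shown hold only these two groups at this place, so it remains open how a plain phenyl, a thiophen-2-yl or a phenyl bearing an amine would behave there. Also open, from the compounds shown here alone, is whether the step keeps its size on a core with a longer chain, and whether it would appear in other cell lines.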